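The source may report more compounds than this note shows. Statements on the series, on what has been measured and on what is new or still open speak of the compounds shown alone.

Working notes on the series. Compound 3 is `CC[C@H](C)[C@H](NC(=O)CN(c1ncnc2c1ncn2C1CCCCO1)C1CC1)C(=O)OCc1ccccc1`. Going by the values given here, in a functional assay on the whole organism (Tail, strain ICR) with Mus musculus as the target, in the tail flick test, with a stated time of 150 min, at a dose of 25 umol/kg by the oral route (on this read-out higher numbers stand for a stronger effect at the one dose given and lower numbers for a weaker effect), compound 3 gives 16.4%, the highest of the three numbers so far, although every step from the other two compounds to it lies within the scatter. Compound 1 is `NC(=O)CC[C@H](NC(=O)CN(c1ncnc2c1ncn2C1CCCCO1)C1CC1)C(=O)OCc1ccccc1` and in this assay compound 1 gives 10.7%. Compound 2 is `O=C(CN(c1ncnc2c1ncn2C1CCCCO1)C1CC1)NCC(=O)OCc1ccccc1` and in this assay compound 2 gives 7.26%. Between these compounds the steps read a number 5.7 percentage points higher from compound 1 to compound 3 (within the scatter), a number 9.1 percentage points higher from compound 2 to compound 3 (within the scatter) and a number 3.4 percentage points lower from compound 1 to compound 2 (within the scatter), all three within the scatter.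

Compound 4 is `C[C@@H](O)[C@H](NC(=O)CN(c1ncnc2c1ncn2C1CCCCO1)C1CC1)C(=O)OCc1ccccc1`. It differs from compound 3 as follows: hydroxy in place of ethyl on a saturated chain carbon bound to two saturated chain carbons Cut one bond further out, the same difference reads sec-butyl to 1-hydroxyethyl. The measured steps that bear on it are those that also alter the group on the saturated chain carbon bound to an amide-type nitrogen and a carbonyl carbon, from hydrogen or from 2-carbamoylethyl to sec-butyl, and neither moved the number beyond the scatter. A return to a smaller group carrying a hydrogen-bond donor and acceptor is therefore expected to give, at most, a step within the scatter, pointing slightly downward, as a number 6.4 percentage points lower from compound 3 to compound 4 (within the scatter). For compound 4 the estimate in this assay is 10%, with a range from 3% to 19%.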

Compound 4, a percentage reported as activity, at one dose (the size of the read-out at that dose, not a potency): 6.53%
Compound 4: the middle estimate sits 3.5 percentage points above what was measured; low and high end bracket the measured number.
By their numbers in this assay, from the lowest: compounds 4, 2, 1 and 3 (each within the scatter of the next).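

In this assay, hydroxy in place of ethyl on a saturated chain carbon bound to two saturated chain carbons gives a number 9.9 percentage points lower from compound 3 to compound 4 (within the scatter), so this change, which also reads sec-butyl to 1-hydroxyethyl, does not separate the two compounds on this read-out. On the saturated chain carbon bound to an amide-type nitrogen and a carbonyl carbon, 1-hydroxyethyl compared with hydrogen gives a number 0.7 percentage points lower from compound 2 to compound 4 (within the scatter) and compared with 2-carbamoylethyl gives a number 4.2 percentage points lower from compound 1 to compound 4 (within the scatter), so hydrogen, 2-carbamoylethyl, sec-butyl and 1-hydroxyethyl on that carbon all stay within the scatter of one another, and the series shows no dependence on this group at the single dose and time given. No measurement is available that bears on the origin of these small differences.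

The compounds shown leave open whether an amine, a carboxylic acid or a longer chain on that same carbon would give a step beyond the scatter. As far as these compounds go, it also remains open whether a methoxy in place of the hydroxy, which would keep the oxygen and remove the hydroxy hydrogen, would read any differently from compound 4 in this assay.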